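A Smaller Aryl Group on the Shared Core

The source may hold more compounds than are shown below. What is called first, only, known or untested is meant among the compounds shown, and "the series" means these compounds.

Compound 1, `Brc1ccc(-c2cn3ccnc3c(-c3ccc4ncn(C5CCCCC5)c4c3)n2)cc1`: 31.2%
Compound 2, `CCc1ccc(-c2cn3ccnc3c(-c3ccc4ncn(Cc5ccccc5)c4c3)n2)cc1`: 61.2%

Within the data shown here, in a functional assay on HCT-116 cells (Homo sapiens) for inhibition, read by sulforhodamine B assay, with a stated time of 48 h, tested at 10 uM (a higher number here means more inhibition at the concentration tested (going by the name of the read-out), a lower number less inhibition), compound 2 gives 61.2%, the higher of the two numbers so far. Among the measured compounds shown here, compound 1 gives 31.2% in this assay, a gap beyond the usual scatter, but the two compounds differ in more than one place, so the two values show only that the number for compound 2 is the higher of the pair and not which change is responsible.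

Compound 3, `Cc1cccc(-c2cn3ccnc3c(-c3ccc4ncn(Cc5ccccc5)c4c3)n2)c1`, is not yet measured. It differs from compound 2 in one place: 3-methylphenyl in place of 4-ethylphenyl on an aromatic carbon. For the measured compounds named here, no pair of measured compounds isolates this kind of change, so the expectation rests on compound 2 alone. A small downward step, possibly within the scatter, is expected: a number 11.2 percentage points lower from compound 2 to compound 3 (beyond the scatter). Compound 3 is therefore estimated to give 50% in this assay, between 30% and 68%.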

Compound 3, a percentage reported as inhibition, at one concentration (the size of the read-out at that concentration, not a potency): 36.7%
Compound 3: middle estimate off by 13.3 percentage points, on the high side, within the range that was stated.
By their numbers in this assay, from the lowest: compounds 1 and 3 (each within the scatter of the next); then compound 2.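

Among these compounds, replacing 4-ethylphenyl with 3-methylphenyl on this aromatic carbon of the shared core gives a number 24.5 percentage points lower from compound 2 to compound 3 (beyond the scatter) in this assay, the first change that can be read at a single place. The number at this position therefore depends on which alkyl-substituted phenyl group it carries, even though both groups hold one six-membered aromatic ring of carbon only and neither has a hydrogen-bond donor or acceptor. Nothing available here accounts for the size of this step.

The change alters both the alkyl chain and its place on the phenyl ring, and no compound shown separates the two. On these data alone, how an amine, a carboxylic acid or a longer chain on that phenyl ring would compare also remains open.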